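The source may report more compounds than this note shows. Statements on the series, on what has been measured and on what is new or still open speak of the compounds shown alone.

Four compounds share one motif: an aromatic ring carrying an oxygen, linked through a double bond to a small five-membered aromatic core. Compound 1 is `Cc1cc(/C=C/c2ccc(O)cc2)[nH]n1` and compound 2 is `COc1ccc(/C=C/c2cc(C)n[nH]2)cc1`. Compound 3 is `COc1ccc(/C=C/c2cc(C)no2)cc1`, and compound 4, `Cc1cc(/C=C/c2ccc(O)cc2)on1`, has not been measured. How the core of compound 3 differs from the core of compound 2 is not broken down here.

In a functional assay on PC-3 cells (Homo sapiens) for cytotoxicity, read by MTT assay, with a stated time of 72 h (on this read-out higher numbers stand for weaker inhibition and lower numbers for stronger inhibition), compound 2 gives 8900 nM, and compound 1 gives 48100 nM. The change between them, (hydrogen in place of methyl on an oxygen on an aromatic ring), made a 5.4-fold higher number from compound 2 to compound 1 (0.73 log units; beyond the scatter).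

For compound 3 this assay reports only a limit, > 100000 nM.

The change from compound 3 to compound 4, (hydrogen in place of methyl on an oxygen on an aromatic ring), is the same change at a place described in the same words, on a different core. With compound 3 already at a limit, the step from compound 3 to compound 4 is expected to read about a step that the limit leaves unreadable from compound 3 to compound 4, and to stay hidden behind a limit. Compound 4 is estimated at 250000 nM, in the range 80000 nM to 1000000 nM, because compound 3 sits at the limit of > 100000 nM in this assay, at which 1 of the 3 values shown sits.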

Compound 4, half-maximal inhibitory concentration: 50200 nM
Estimate against measurement, compound 4: 5.0-fold (0.70 log units) above; the whole stated range lies above it.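

Compound 3 is recorded in this assay only as a limit, > 100000 nM. The swap of methoxy to hydroxy therefore reads as an at least 1.9-fold lower number from compound 3 to compound 4 (0.29 log units; that floor lies within the scatter), which gives the direction on this core but not the true size of the step. Even so, the change does not carry from one core to the other as a fixed shift, although these two pairs alone cannot show why the cores part ways, and the comparison reads: the same change on two cores in this assay, a 5.4-fold higher number (0.73 log units; beyond the scatter) from compound 2 to compound 1 and an at least 1.9-fold lower number (0.29 log units; that floor lies within the scatter) from compound 3 to compound 4, at least 10-fold (1.03 log units) apart, beyond the scatter of two such steps

Among the compounds shown here, only two cores carry this change here, so whether a third core would follow either pattern remains open. On these data alone, it also remains open how an amine in place of the hydroxy group, or a longer chain than methyl on that oxygen, would read in this assay.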